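This account rests on a few compounds, and the source may have more. Where it says the series, first, only, none or still open, it means among the compounds named here.

The measured compounds and their results:

Compound 1 `O=C(c1ccc(NCc2cncn2Cc2ccc(-c3ccccc3)cc2)cc1-c1ccccc1)N1CCCCC1` in a toxicity assay on NIH3T3 cells (Mus musculus) for cytotoxicity, read by resazurin assay (a lower number here means that less compound is needed, a higher number that more compound is needed for the effect), gives > 1000 nM, a limit of the assay and not a number.
Compound 2 `COC(=O)c1ccc(NCc2cncn2Cc2cccc(C#N)c2)cc1-c1ccccc1` in this assay gives > 10000 nM, likewise a limit.
Compound 3 `Fc1ccc(Cn2cncc2CNc2ccc(-c3nc4ccccc4s3)c(-c3ccccc3)c2)c(F)c1` in this assay gives > 1000 nM, again a limit.

Compound 1 therefore stands not on a number but on a boundary: its result is the limit of > 1000 nM in this assay, at which 2 of the 3 values shown sit, while the only other kind of result among the three is the limit of > 10000 nM in this assay, at which 1 of the 3 values shown sits. No pair among these three compounds differs in just one place, so no step between measured compounds can be stated; all that can be said is that none of the three reached a measurable cytotoxic concentration in this assay.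

Compound 4 `CN(C)C(=O)c1ccc(NCc2cncn2Cc2ccc(-c3ccccc3)cc2)cc1-c1ccccc1` is the untested compound. Relative to compound 1 the change is dimethylamino in place of piperidin-1-yl on a carbonyl carbon. The amide nitrogen keeps its two carbon substituents but loses the ring that joined them.

For the measured compounds named here, because compound 1 sits at the limit of > 1000 nM in this assay, at which 2 of the 3 values shown sit, there is no measured step from which a direction could be read, and the expectation is for no shift beyond the usual scatter. Compound 4 is expected to give 3000 nM in this assay, in a range from 1000 nM to 15000 nM, most likely reported again as a limit. The estimated step that the limit leaves unreadable from compound 1 to compound 4 is expected to be essentially flat.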

Compound 4, half-maximal effective concentration: > 1000 nM
Compound 4 was reported as a limit; the forecaster's own chance of this, stated with the estimate: 80%; the middle value does not contradict the limit.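

For the compounds shown here, compound 1 and compound 4 both end in this assay at a limit of the assay and not at a number, so no step between them can be read. The compounds shown leave open at what concentration either would show cytotoxicity, and whether dimethylamino in place of piperidin-1-yl on a carbonyl carbon alters that concentration at all.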